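Lengthening the amine chain: from compound 2 to compound 3

The source may hold more compounds than are shown below. What is called first, only, known or untested is meant among the compounds shown, and "the series" means these compounds.

Measured so far in a functional assay on MCF7 cells (Homo sapiens) for antiproliferative activity, read by MTT assay, with a stated time of 72 h; on this read-out lower numbers stand for stronger inhibition and higher numbers for weaker inhibition:
compound 1 `CCCCCCCCNC[C@@H]1OC[C@H](N)[C@@H]1O` gives 96600 nM
compound 2 `CCCCCCCCCCCNC[C@@H]1OC[C@H](N)[C@@H]1O` gives 6770 nM

Of the two measured compounds, compound 2 stands lowest in this assay at 6770 nM on this read-out. Compound 3 `CCCCCCCCCCCCCCNC[C@@H]1OC[C@H](N)[C@@H]1O` is the next chain extension, with propyl in place of hydrogen on a saturated chain carbon, ten or more bonds along the chain from an amine nitrogen as its difference from compound 2: propyl in place of hydrogen on a saturated chain carbon, ten or more bonds along the chain from an amine nitrogen. For the measured compounds named here, only one measured step bears on this, a 14-fold lower number from compound 1 to compound 2 (1.15 log units; beyond the scatter), for the same propyl in place of hydrogen, eight bonds along the chain from an amine nitrogen. A single step cannot show whether the trend continues. A smaller step in the same direction is therefore expected, with a 2.7-fold lower number from compound 2 to compound 3 (0.43 log units; beyond the scatter) as the estimate in this assay. The estimated value for compound 3 is 2500 nM, within an expected range of 800 nM to 7500 nM in this assay.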

Compound 3, half-maximal inhibitory concentration: 720 nM
Beside the measured number, compound 3's estimate is 3.5-fold (0.54 log units) above it; measured number outside the range, below it.
By their numbers in this assay, from the lowest: compound 3; then compound 2; then compound 1.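

In this assay propyl in place of hydrogen on a saturated chain carbon gives a 9.4-fold lower number from compound 2 to compound 3 (0.97 log units; beyond the scatter) and so the fall first seen eight bonds along the chain carries on at this further place. Taken as one change, hexyl in place of hydrogen gives a 130-fold lower number from compound 1 to compound 3 (2.13 log units; beyond the scatter) and compound 3 is the most potent of the three. No evidence on hand bears on the reason for this trend.

Still open, as far as these compounds go, is whether a longer chain lowers the number further or the trend ends. Also open, from the compounds shown here alone, is how a chain ending in a carboxylic acid or an amine would compare with compound 3.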